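This account rests on a few compounds, and the source may have more. Where it says the series, first, only, none or still open, it means among the compounds named here.

Measured so far:
compound 1 `O=C(Nc1nnc(-c2cccc(O)c2O)s1)c1ccc(Cl)cc1` — 30200 nM
compound 2 `Cc1ccc(C(=O)Nc2nnc(-c3ccc(O)c(O)c3)s2)cc1` — 34000 nM

In a functional assay, with a stated time of 30 min, in the absence of a further agent (a lower number here means a stronger inhibitor, a higher number a weaker inhibitor), compound 1 gives 30200 nM, the lower of the two numbers recorded, while compound 2 gives 34000 nM; the gap between them lies within the scatter, so the two compounds stand together and neither can be called the more potent. Both numbers sit in the weak-inhibitor range.

Compound 3 `O=C(Nc1nnc(-c2cccc(O)c2O)s1)c1ccccc1` has not yet been measured. Relative to compound 1 the change is hydrogen in place of chloro on an aromatic carbon. Going by the values given here, no pair of measured compounds differing in one place is available, so the size of this step cannot be read from the series; the expectation therefore rests on the number for compound 1 alone. Removal of a single chloro at this position is expected to shift the number by little, if at all, with any drift more likely toward a higher number than a lower one. Compound 3 is expected at 40000 nM, within 15000 nM to 110000 nM. The step of a 1.3-fold higher number from compound 1 to compound 3 (0.12 log units; within the scatter) is thus expected to remain within or only just beyond the scatter.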

Compound 3, half-maximal inhibitory concentration: 22300 nM
Estimate against measurement, compound 3: 1.8-fold (0.25 log units) above; the range from low to high includes it.
By their numbers in this assay, from the lowest: compounds 3, 1 and 2 (each within the scatter of the next).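

In this assay, going by these compounds alone, the exchange of 4-chlorophenyl for phenyl gives the first single-place step, a 1.4-fold lower number from compound 1 to compound 3 (0.13 log units; within the scatter), and this step lies within the scatter. At this position, on an aromatic carbon para to a large group, the chloro can therefore give way to hydrogen with no measurable consequence, and both compounds remain in the weak-inhibitor range. Nothing available accounts for this result.

Two compounds with one substituent pair say little about the position as a whole: an amine, a carboxylic acid or a methoxy group there could still move the number beyond the scatter. Within the data shown here, no single-place step yet isolates the arrangement of the two hydroxyl groups on the other aromatic ring.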